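The source may report more compounds than this note shows. Statements on the series, on what has been measured and on what is new or still open speak of the compounds shown alone.

In a functional assay on HepG2 cells (Homo sapiens) for antiproliferative activity, read by fluorescence and resazurin assay, with a stated time of 48 h (on this read-out lower numbers stand for stronger inhibition and higher numbers for weaker inhibition), compound 1 (`CCOc1ccc(NC(=O)c2cc3cc(Br)ccc3oc2=O)cc1`) gives 37000 nM. Compound 3 (`CCOc1ccc2nc(Cl)c(/C=N/NC(=O)c3cc4ccccc4oc3=O)cc2c1`), at 33100 nM, lies within the scatter of compound 1, while compound 2 (`O=C(N/N=C/c1cccnc1)c1cc2ccccc2oc1=O`), at 15900 nM, has a lower number, beyond the scatter. Compound 4 (`CCOc1ccc(NC(=O)c2cc3ccccc3oc2=O)cc1`) differs from compound 1 by one change, hydrogen in place of bromo on an aromatic carbon. Going by the values given here, no measured pair shows this change alone, so the data give no firm direction. The measured numbers do stay close, from compound 2 at 15900 nM to compound 1 at 37000 nM, so only a small shift toward a lower number is expected, probably within the scatter. The expected step is a 1.3-fold lower number from compound 1 to compound 4 (0.12 log units; within the scatter). For compound 4 the estimated value is 28000 nM, with an expected range from 11000 nM to 65000 nM.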

Compound 4, half-maximal inhibitory concentration: 10400 nM
Estimate against measurement, compound 4: 2.7-fold (0.43 log units) above, outside the stated range (below it).
By their numbers in this assay, from the lowest: compounds 4 and 2 (each within the scatter of the next); then compounds 3 and 1 (each within the scatter of the next).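

In this assay, hydrogen in place of bromo gives a 3.6-fold lower number from compound 1 to compound 4 (0.55 log units; beyond the scatter), a step beyond the usual scatter. Going by these compounds alone, this pair is the first to isolate the change, and it shows that this aromatic carbon of the shared core affects the read-out, with the bromo compound having the higher number. Nothing available explains the shift. Whether other groups here would raise the number as bromo does remains open, as the compounds shown carry no amine or carboxylic acid at this carbon. One pair also cannot show whether the step would hold on another core.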